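Phenylpiperazine variation on the triazinedione butyl chain

The source may report more compounds than this note shows. Statements on the series, on what has been measured and on what is new or still open speak of the compounds shown alone.

Among the measured compounds shown here, compound 3 `Cn1c(=O)cnn(CCCCN2CCN(c3c(Br)cccc3C#N)CC2)c1=O` gives 450 nM in an assay for displacement of a labelled ligand from Adrenergic receptor alpha-1 (Homo sapiens) (a higher number here means a weaker inhibitor, a lower number a stronger inhibitor), the highest number among the three compounds measured so far. Compound 1 `CCOc1ccccc1N1CCN(CCCCn2ncc(=O)n(C)c2=O)CC1` gives 1.8 nM in this assay, and compound 2 `Cn1c(=O)cnn(CCCCN2CCN(c3ccccc3C#N)CC2)c1=O` gives 7.3 nM. Both steps leading to compound 3 are large and run the same way: a 250-fold higher number from compound 1 to compound 3 (2.40 log units; beyond the scatter) and a 62-fold higher number from compound 2 to compound 3 (1.79 log units; beyond the scatter). The remaining measured step, a 4.1-fold higher number from compound 1 to compound 2 (0.61 log units; beyond the scatter), is modest by comparison and concerns only the substituent on the aryl ring.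

Compound 4 `Cn1c(=O)cnn(CCCCN2CCN(c3cccc(O)c3)CC2)c1=O` alters the same part of the series: 3-hydroxyphenyl in place of 2-bromo-6-cyanophenyl on an amine nitrogen in a ring. For the measured compounds named here, the bromo substituent introduced in a 62-fold higher number from compound 2 to compound 3 (1.79 log units; beyond the scatter) leaves, and the nitrile leaves with it; a hydroxy group on the phenyl ring enters, for which no measured precedent exists in this set. The two large steps into compound 3 bear directly on this change, since both show that the aryl group on the piperazine nitrogen moves this assay strongly. A large step in this assay is therefore expected, downward in number from compound 3, with the expected size being a 45-fold lower number from compound 3 to compound 4 (1.65 log units; beyond the scatter). Compound 4 is estimated at 10 nM in this assay, within a range of 2 nM to 60 nM.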

Compound 4, inhibition constant: > 10000 nM
Compound 4: no number, only a limit; the forecaster's own chance of this, stated with the estimate: 2%; middle value at least 1000-fold (3.00 log units) away from the limit.
By their numbers in this assay, from the lowest: compound 1; then compound 2; then compound 3. At a limit, above all of these: compound 4.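

In this assay compound 4 stands at a limit of the assay, not at a number: the limit of > 10000 nM in this assay, at which 1 of the 4 values shown sits.

All three steps into it are large, beyond the scatter and run the same way, and each is a bound only: an at least 22-fold higher number from compound 3 to compound 4 (1.34 log units; beyond the scatter), an at least 1300-fold higher number from compound 2 to compound 4 (3.13 log units; beyond the scatter) and an at least 5500-fold higher number from compound 1 to compound 4 (3.74 log units; beyond the scatter). All four compounds carry a phenyl ring on the amine nitrogen in a ring, so that ring alone does not hold the number down; what it carries decides the outcome, and 3-hydroxyphenyl, which has neither the bromo nor the nitrile of 2-bromo-6-cyanophenyl, does not return the number towards that of the 2-cyanophenyl or 2-ethoxyphenyl compounds.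

Both the group and its place on the ring differ in these steps, so the hydroxy group cannot be separated from its position; 2-hydroxyphenyl, 3-methoxyphenyl and 3-ethoxyphenyl would be the informative comparisons. From the compounds shown here alone, how far the number of compound 4 lies past its limit stays open, as does the standing of an unsubstituted phenyl group on the same chain.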